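A few compounds are considered here, and "the series" means these few. Any claim that something is new, unique, unknown or untested is made for them only; others in the source may bear on it.

Compound 1 `COC(=O)[C@H](CCSC)NC(=O)c1ccc(NCc2cncn2Cc2cccc(C#N)c2)cc1-c1ccccc1` gives > 10 uM.
Compound 2 `COC(=O)[C@H](CCSC)NC(=O)c1ccc(CN(Cc2c[nH]cn2)Cc2c[nH]cn2)cc1-c1ccccc1C` gives > 10 uM.
Compound 3 `CSCNC(=O)c1ccc(NCc2cncn2Cc2ccc(C#N)cc2)cc1-c1ccccc1` gives > 10 uM.

All three compounds were tested in a functional assay on NIH3T3 cells (Mus musculus); on this read-out lower numbers stand for an effect already at smaller amounts and higher numbers for an effect only at larger amounts of compound. For compound 1 the value > 10 uM is a limit of the assay and not a measured number. The same holds for compound 2 and for compound 3, so that the limit of > 10 uM in this assay, at which 3 of the 3 values shown sit, is the only thing the three results have in common: none of them shows an effect within the range that was tested. Among the compounds with values here, there is no step between two measured compounds that would show how a change in structure moves the read-out.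

The next compound, compound 4 `COC(=O)[C@H](CCSC)NC(=O)c1ccc(NCc2cncn2Cc2cccc(C)c2)cc1-c1ccccc1`, differs from compound 1 in a single place: methyl in place of cyano on an aromatic carbon. Nothing among the three measured compounds tells how this change should move the result.

With compound 1 sitting at the limit, the expected step that the limit leaves unreadable from compound 1 to compound 4 in this assay is none beyond the scatter, and compound 4 is expected most likely to remain at the same limit. Taken as a number, the estimate for compound 4 is 15 uM, with a range from 5 uM to 50 uM.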

Compound 4, concentration for half-maximal effect: > 10 uM
Compound 4: only a limit was reported; the forecaster's own chance of this, stated with the estimate: 80%; the middle value lies beyond the limit too.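

Compound 1 and compound 4 both rest on a limit of the assay and not on a measured number, so the exchange of cyano for methyl yields no step that can be read: the limit of > 10 uM in this assay, at which 4 of the 4 values shown sit.

The compounds shown leave open which change in structure, if any, would bring a measurable effect in this assay, and whether cyano and methyl differ there at all.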